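From a Carboxylic Acid to a Propanoyl Ester

A few compounds are considered here, and "the series" means these few. Any claim that something is new, unique, unknown or untested is made for them only; others in the source may bear on it.

Compound 3 `Nc1ccc(-c2cc(=O)c3c(N)c(F)c(C(=O)O)c(F)c3o2)cc1F` stands only at a limit in a functional assay on HeLa cells (Homo sapiens) for cytotoxicity, read by neutral red uptake, with a stated time of 3 days; a lower number here means a stronger inhibitor, a higher number a weaker inhibitor: in that assay compound 3 gives > 100000 nM, which is a limit of the assay and not a number. Compound 1 `Nc1ccc(-c2cc(=O)c3c(N)c(F)c(CO)c(F)c3o2)cc1F` gives 24000 nM in this assay, so the step of an at least 4.1-fold higher number from compound 1 to compound 3 (0.61 log units; beyond the scatter) is read only as a bound. Compound 2 `Nc1ccc(-c2cc(=O)c3c(N)c(F)c(Cl)c(F)c3o2)cc1F` gives > 100000 nM, again a limit. The step that the two limits leave unreadable from compound 2 to compound 3 is unreadable because of the limit of > 100000 nM in this assay, at which 2 of the 3 values shown sit. Compound 4 `CCC(=O)OCc1c(F)c(N)c2c(=O)cc(-c3ccc(N)c(F)c3)oc2c1F` carries (propanoyloxy)methyl in place of carboxy on an aromatic carbon. Among the compounds with values here, the only measured step that bears on this change is an at least 4.1-fold higher number from compound 1 to compound 3 (0.61 log units; beyond the scatter), taken in reverse, since the carboxy that accompanied the limit leaves. The expectation is therefore a downward step an at least 6.6-fold lower number from compound 3 to compound 4 (0.82 log units; beyond the scatter) in this assay back toward compound 1. Compound 4 is estimated at 15000 nM, within 4000 nM to 60000 nM.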

Compound 4, half-maximal inhibitory concentration: 69000 nM
Estimate against measurement, compound 4: 4.6-fold (0.66 log units) below; measured number outside the range, above it.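

Propanoyl on the oxygen of the hydroxymethyl gives a 2.9-fold higher number from compound 1 to compound 4 (0.46 log units; beyond the scatter), so at this position, ortho to two fluoro groups, two substituents now carry real numbers in this assay. Against the other two compounds only floors can be read, an at least 1.4-fold lower number from compound 3 to compound 4 (0.16 log units; that floor lies within the scatter) and an at least 1.4-fold lower number from compound 2 to compound 4 (0.16 log units; that floor lies within the scatter). These floors rest on limits of the assay and not on numbers: the limit of > 100000 nM in this assay, at which 2 of the 4 values shown sit.

On these data alone, whether an acetyl ester, a longer ester chain or an aminomethyl group on this carbon would give a lower or a higher number stays open.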